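The source may hold more compounds than are shown below. What is called first, only, known or untested is meant among the compounds shown, and "the series" means these compounds.

- compound 1 `O=C1c2c[n+]([O-])c3ccccc3c2C(=O)c2c1c1ccccc1n2Cc1cn([C@@H]2C[C@H](O)[C@@H](CO)O2)nn1`: 630 nM
- compound 2 `CN1CCN(CCCCn2c3c(c4ccccc42)C(=O)c2c[n+]([O-])c4ccccc4c2C3=O)CC1`: 80 nM

In a toxicity assay on L02 cells (Homo sapiens) for cytotoxicity, read by MTT assay, with a stated time of 72 h (a lower number here means a stronger inhibitor, a higher number a weaker inhibitor), compound 1 gives 630 nM, the higher of the two numbers and so the weaker result. Compound 2 reads 80 nM, and that gap lies beyond the usual scatter of repeat measurements.

The next compound to be tested is compound 3 `CC1(C)OC[C@H](Cn2cc(Cn3c4c(c5ccccc53)C(=O)c3c[n+]([O-])c5ccccc5c3C4=O)nn2)O1`, which keeps the shared core of compound 1 and changes one group: (2,2-dimethyl-1,3-dioxolan-4-yl)methyl in place of 4-hydroxy-5-(hydroxymethyl)oxolan-2-yl on an aromatic nitrogen. In words, (2,2-dimethyl-1,3-dioxolan-4-yl)methyl stands in place of 4-hydroxy-5-(hydroxymethyl)oxolan-2-yl on an aromatic nitrogen. Among the measured compounds shown here, no pair of measured compounds isolates this swap, so the data give no direct guide to its effect. Compound 2, at 80 nM, shows only that a quite different side chain on the shared core can come with a far lower number, which argues for a wide range.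

The expected change is modest and toward a lower number, possibly no larger than the scatter: a 1.6-fold lower number from compound 1 to compound 3 (0.20 log units; within the scatter). For compound 3 the estimated value is 400 nM, with an expected range from 120 nM to 1300 nM.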

Compound 3, half-maximal inhibitory concentration: 470 nM
Compound 3: middle estimate off by 1.2-fold (0.07 log units), on the low side, within the range that was stated.
By their numbers in this assay, from the lowest: compound 2; then compounds 3 and 1 (each within the scatter of the next).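

In this assay, putting (2,2-dimethyl-1,3-dioxolan-4-yl)methyl in place of 4-hydroxy-5-(hydroxymethyl)oxolan-2-yl on the aromatic nitrogen gives a 1.3-fold lower number from compound 1 to compound 3 (0.13 log units; within the scatter). Among the compounds shown here, this is the first direct reading at this position, and it shows that two quite different rings can sit here without a difference that can be told from assay scatter, even though the group that leaves has 2 hydrogen-bond donors and 3 defined stereocentres, while the group that enters has 0 donors and 1 stereocentre. No measurement shown here explains this outcome, so it stands as an observation about this one pair.

Both groups have 8 heavy atoms, so this pair says nothing about how much the size of the group at this position matters. It also leaves open whether a much smaller group such as methyl, or a group of another kind such as a carboxylic acid or an amine, would give a number beyond the scatter from that of compound 1.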